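An aryl exchange on the shared core

This account rests on a few compounds, and the source may have more. Where it says the series, first, only, none or still open, it means among the compounds named here.

In a functional assay on MCF7 cells (Homo sapiens) for antiproliferative activity, read by MTT assay, with a stated time of 48 h (on this read-out higher numbers stand for weaker inhibition and lower numbers for stronger inhibition), compound 1 (`Cc1cccc(-c2nn(-c3ccccc3)cc2C(Nc2nc3ccccc3s2)c2c(O)ccc3ccccc23)c1`) gives 17300 nM and compound 2 (`Oc1ccc2ccccc2c1C(Nc1nc2ccccc2s1)c1cn(-c2ccccc2)nc1-c1ccc(I)cc1`) gives 18900 nM on the same read-out. Compound 3 (`COc1ccc2nc(NC(c3cn(-c4ccccc4)nc3-c3ccc(Cl)cc3)c3c(O)ccc4ccccc34)sc2c1`) gives 23700 nM and so stands within the scatter of both. Compound 4 (`COc1cccc(-c2nn(-c3ccccc3)cc2C(Nc2nc3ccc(OC)cc3s2)c2c(O)ccc3ccccc23)c1`) differs from compound 3 by 3-methoxyphenyl in place of 4-chlorophenyl on an aromatic carbon with 3-methoxyphenyl in place of 4-chlorophenyl on an aromatic carbon. Among the compounds with values here, the one measured step of this kind, a 1.1-fold higher number from compound 1 to compound 2 (0.04 log units; within the scatter) for 4-iodophenyl in place of 3-methylphenyl, lies within the scatter. No step beyond the scatter is therefore expected in this assay for this change. The expected step is a 1.1-fold lower number from compound 3 to compound 4 (0.05 log units; within the scatter) and stays within the scatter. Compound 4 is estimated at 21000 nM with an expected range from 11000 nM to 40000 nM on this read-out.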

Compound 4, half-maximal inhibitory concentration: 62600 nM
Beside the measured number, compound 4's estimate is 3.0-fold (0.47 log units) below it; the whole stated range lies below it.
By their numbers in this assay, from the lowest: compounds 1, 2 and 3 (each within the scatter of the next); then compound 4.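

In this assay this position on the five-membered aromatic ring proves sensitive to the aryl group it carries: the exchange of 4-chlorophenyl for 3-methoxyphenyl gives a 2.6-fold higher number from compound 3 to compound 4 (0.42 log units; beyond the scatter) and lies beyond the scatter, whereas the earlier exchange gave only a 1.1-fold higher number from compound 1 to compound 2 (0.04 log units; within the scatter) and stayed within it. The weaker inhibition of compound 4 thus shows that aryl exchange here is not always silent, though the step remains modest. Nothing measured here offers an explanation for this step.

The compounds shown leave open whether 3-methoxyphenyl would give a similar step on the core of compound 1. They also leave open how this position would respond to an aryl group bearing an amine or a carboxylic acid.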